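This account rests on a few compounds, and the source may have more. Where it says the series, first, only, none or still open, it means among the compounds named here.

Measured so far in a functional assay on KB 3-1 cells (Homo sapiens) for antiproliferative activity, read by MTT assay; a lower number here means a stronger inhibitor, a higher number a weaker inhibitor:
compound 1 `C=CCC[C@H]1CC(=O)[C@@H]2C=CC(=O)[C@H]12` gives 16300 nM
compound 2 `O=C1C=C[C@H]2C(=O)C=C[C@@H]12` gives 6000 nM
compound 3 `C[C@@H]1[C@@H]2[C@@H](CC(=O)[C@H]2C)C[C@H]1O[Si](c1ccccc1)(c1ccccc1)C(C)(C)C` gives 7400 nM

Of these three, compound 3 stands within the scatter of compound 2, whereas compound 1 shows a higher number than compound 3, a gap beyond the scatter.

Compound 4 `CC(C)=CC[C@@H]1C(=O)C[C@H]2C[C@@H](O[Si](c3ccccc3)(c3ccccc3)C(C)(C)C)[C@H](C)[C@H]21` has not yet been measured. Its structure departs from that of compound 3 by one change, (2-methylprop-1-en-1-yl in place of hydrogen on a saturated chain carbon bound to a saturated ring carbon), which places 2-methylprop-1-en-1-yl in place of hydrogen on a saturated chain carbon bound to a saturated ring carbon.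

Among the measured compounds shown here, no measured pair of compounds differs in one place only, so the data offer no direct guide to this change. The expectation therefore rests on the spread of the three values, and no step beyond the scatter is expected in this assay in either direction. The estimated change, a 1.1-fold higher number from compound 3 to compound 4 (0.03 log units; within the scatter), is expected to stay within the scatter. For compound 4 the estimated value is 8000 nM, with an expected range from 3000 nM to 20000 nM in this measurement.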

Compound 4, half-maximal inhibitory concentration: 21700 nM
Estimate against measurement, compound 4: 2.7-fold (0.43 log units) below; the measured number lies above the stated range.
By their numbers in this assay, from the lowest: compounds 2 and 3 (each within the scatter of the next); then compounds 1 and 4 (each within the scatter of the next).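

In this assay, among the compounds shown here, 2-methylprop-1-en-1-yl in place of hydrogen on a saturated chain carbon bound to a saturated ring carbon gives a 2.9-fold higher number from compound 3 to compound 4 (0.47 log units; beyond the scatter), the first comparison here between compounds that differ in one place. At this position, therefore, the change weakens the compound by a modest step beyond the scatter, an exchange that can also be read as methyl to 3-methylbut-2-en-1-yl. Nothing measured accounts for this weakening.

The compounds shown leave open whether an ethyl group, a saturated 3-methylbutyl chain, an amine or a carboxylic acid at this place would give a number closer to that of compound 3 or closer to that of compound 4. Resting on a single pair, they also leave open whether the same change would produce a similar step on another core.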